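Pyridyl-alkenoic acids as thromboxane synthase inhibitors: trimming the acid

The compounds below may be only part of what the source reports. "The series", "measured", "known", "first", "only" and "open" are said of these compounds alone.

Measured so far:
compound 1, `CC(C)(O)C(CCC/C=C(\c1ccccc1)c1cccnc1)C(=O)O` — 42 nM
compound 2, `O=C(O)CCCC/C=C(\c1cccnc1)c1cccc([N+](=O)[O-])c1` — 73 nM
compound 3, `O=C(O)CCCC/C=C(\c1cccnc1)c1ccccc1Br` — 130 nM

All three were run in an assay (Equus caballus) for inhibition of Thromboxane-A synthase (Homo sapiens), using microsomes; a higher number here means a weaker inhibitor, a lower number a stronger inhibitor. Compound 1 gives the lowest number of the three. Compound 2 lies nearest to it, and the two values sit within the scatter of each other, so no order between compound 1 and compound 2 can be read from them. Compound 3 gives the highest number and its gap from compound 1 is beyond the scatter.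

The next compound, compound 4 with structure `O=C(O)CCC/C=C(\c1ccccc1)c1cccnc1`, is not yet measured in this assay. It differs from compound 1 in one place: carboxy in place of 1-carboxy-2-hydroxy-2-methylpropyl on a saturated chain carbon, three bonds along the chain from a double-bonded chain carbon. The carboxy group remains on the chain, so the acid end of the series is kept while the rest of the substituent is dropped.

Within the data shown here, no measured pair differs in this one place, so the size of the step rests on expectation only. The step from compound 1 to compound 4 is expected to be small, most likely a modest move to a higher number or none beyond the scatter. For compound 4 the value is estimated at 65 nM, with a range of 20 nM to 200 nM; this corresponds to an expected 1.5-fold higher number from compound 1 to compound 4 (0.19 log units; within the scatter).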

Compound 4, half-maximal inhibitory concentration: 30 nM
For compound 4 the middle estimate is 2.2-fold (0.34 log units) above the measured one; the measured number falls inside the stated range.
By their numbers in this assay, from the lowest: compounds 4, 1, 2 and 3 (each within the scatter of the next, the first and the last beyond it).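

In this assay, carboxy in place of 1-carboxy-2-hydroxy-2-methylpropyl at this position gives a 1.4-fold lower number from compound 1 to compound 4 (0.15 log units; within the scatter), so compound 1 and compound 4 cannot be ordered. The position therefore tolerates a drop from 8 heavy atoms in the substituent to 3 without a change beyond the scatter, and the hydrogen-bond donor and acceptor that leave with it are not needed to keep the number in this range. No measurement at hand gives a reason for this result.

On these data alone, whether the acid itself is needed at this position stays open: an ester, an amide or a tetrazole in place of carboxy would test that, and a longer chain carrying carboxy would show how far the acid can sit from the double-bonded chain carbon. Compound 2 and compound 3 differ from compound 4 in more than one place, so the effect of their nitro and bromo groups stays unseparated from that of the chain, and a nitro or bromo group on the core of compound 4 would be needed to isolate it.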